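Moving the Furan Attachment Point in an Ester Side Chain

The source may hold more compounds than are shown below. What is called first, only, known or untested is meant among the compounds shown, and "the series" means these compounds.

Compound 1, `CC(C)=CC[C@@H](OC(=O)c1ccoc1)C1=CC(=O)c2c(O)ccc(O)c2C1=O`: in a functional assay on DU-145 cells (Homo sapiens) for cytotoxicity, read by MTT assay (on this read-out lower numbers stand for stronger inhibition and higher numbers for weaker inhibition), compound 1 is reported only as the limit > 100000 nM.
Compound 2, `CC(C)=CC[C@@H](OC[C@@H](C)O)C1=CC(=O)c2c(O)ccc(O)c2C1=O`: compound 2 gives 14300 nM.
Compound 3, `CC(C)=CC[C@@H](OC(=O)C1CCCO1)C1=CC(=O)c2c(O)ccc(O)c2C1=O`: compound 3 gives 10500 nM.

Compound 1 stands at the edge of what this assay can report: its value is a limit of the assay, (the limit of > 100000 nM in this assay, at which 1 of the 3 values shown sits), and not a number. Compound 4, `CC(C)=CC[C@@H](OC(=O)c1ccco1)C1=CC(=O)c2c(O)ccc(O)c2C1=O`, differs from compound 1 in one place: furan-2-yl in place of furan-3-yl on a carbonyl carbon. Among the compounds with values here, no measured pair changes only the attachment point of the furan ring, so no step bears directly on this move. The two steps that start from compound 1 replace more than that: an at least 6.9-fold lower number from compound 1 to compound 2 (0.84 log units; beyond the scatter) and an at least 9.5-fold lower number from compound 1 to compound 3 (0.97 log units; beyond the scatter). Both lead away from the limit, and the gap between their products is small: a 1.4-fold lower number from compound 2 to compound 3 (0.13 log units; within the scatter). Compound 3 carries an oxolan-2-yl group on the carbonyl carbon, the saturated counterpart of the furan-2-yl that enters in compound 4. With compound 1 known only as a limit, the size of the step to compound 4 cannot be fixed; a modest move toward the region of compound 3 is expected, that is an estimated at least 1.6-fold lower number from compound 1 to compound 4 (0.22 log units; that floor lies within the scatter). Compound 4 is therefore expected near 60000 nM, within 15000 nM to 300000 nM, with a real chance that it too is reported only as a limit.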

Compound 4, half-maximal inhibitory concentration: > 100000 nM
Compound 4: a limit, no number; the forecaster's own chance of this, stated with the estimate: 45%; at least 1.6-fold (0.22 log units) between middle value and limit.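

In this assay the value of compound 4 is a limit and not a number, as is that of compound 1, so the step between these two cannot be read and moving the ring attachment from furan-3-yl to furan-2-yl shows no measurable change in either direction. What compound 4 adds lies in the comparison with its saturated counterpart on the same carbonyl carbon: there is an at least 9.5-fold higher number from compound 3 to compound 4 (0.97 log units; beyond the scatter) and so furan-2-yl does not stand in for oxolan-2-yl here, just as furan-3-yl did not. Replacing the whole side chain gives a similar picture, with an at least 6.9-fold higher number from compound 2 to compound 4 (0.84 log units; beyond the scatter) and among the compounds shown both furan esters, and no others, now sit at the same limit: the limit of > 100000 nM in this assay, at which 2 of the 4 values shown sit.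

On these data alone, how far either furan ester lies beyond that limit remains open, and so does whether the two differ at all. Also open, as far as these compounds go, is whether a numerical value on this carbonyl carbon is confined to the oxolan-2-yl group or would also be reached with a pyrrolidin-2-yl amine or a longer open alkyl chain.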